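Removing the Nitroso Group from a Shared Urea Core

The compounds below may be only part of what the source reports. "The series", "measured", "known", "first", "only" and "open" are said of these compounds alone.

Of the compounds shown here, three have been tested in a functional assay on HEp-2 cells (Homo sapiens) for cytotoxicity; a lower number here means that less compound is needed, a higher number that more compound is needed for the effect. Compound 1 `CN(N=O)C(=O)NC[C@H]1O[C@@H](n2ccc(=O)[nH]c2=O)[C@H](O)[C@@H]1O` stopped at the limit of the assay, > 50 uM. Compound 3 `CN(N=O)C(=O)NC[C@H]1O[C@@H](n2ccc(N)nc2=O)[C@H](O)[C@@H]1O` also gave only a limit, > 50 uM. Compound 2 `CN(N=O)C(=O)N[C@H]1[C@@H](O)[C@H](n2ccc(N)nc2=O)O[C@@H]1CO` likewise reached no number, only the limit > 50 uM. Compound 2 therefore stands exactly where the other two stand: the limit of > 50 uM in this assay, at which 3 of the 3 values shown sit. Among the measured compounds shown here, no measured pair differs in a single place, so no step in this assay has been seen.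

Compound 4 `CNC(=O)N[C@H]1[C@@H](O)[C@H](n2ccc(N)nc2=O)O[C@@H]1CO` has not yet been measured. It differs from compound 2 in one place (a hydrogen atom in place of a group of 2 heavy atoms (1 nitrogen, 1 oxygen; no ring), on an amide-type nitrogen), on the amide-type nitrogen whose other neighbours are a carbonyl carbon and a saturated chain carbon. With every measured value sitting at the limit, the three compounds give no hint that any change moves this read-out. The expected step, a step that the limit leaves unreadable from compound 2 to compound 4, is therefore none beyond the scatter, and a limit is again the most likely report. Compound 4 is expected to give about 80 uM in this assay, with a plausible range from 30 uM to 300 uM.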

Compound 4, concentration for half-maximal effect: > 60 uM
Compound 4: a limit, no number; the forecaster's own chance of this, stated with the estimate: 85%; the middle value lies beyond the limit too.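

In this assay compound 2 gives only a limit, > 50 uM. Compound 4 likewise gives only a limit, > 60 uM. The step between these two compounds therefore cannot be read. The compounds shown leave open whether swapping the nitroso group for a hydrogen atom changes this read-out at all.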